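Series notes: chloro in place of hydroxy, compound 4

The source may report more compounds than this note shows. Statements on the series, on what has been measured and on what is new or still open speak of the compounds shown alone.

Going by the values given here, compound 3 `Oc1ccc2[nH]c(-c3nc(-c4ccccc4)no3)cc2c1` gives 13000 nM in a functional assay on MIA PaCa-2 cells (Homo sapiens) for antiproliferative activity, read by WST assay, with a stated time of 72 h (a lower number here means a stronger inhibitor, a higher number a weaker inhibitor), the lowest of the two numbers measured so far. Compound 1 `Cc1noc(-c2cc3ccccc3[nH]2)n1` gives 30500 nM in this assay. Compound 2 `Cc1noc(-c2cc3cc(Cl)ccc3[nH]2)n1` reaches only a limit in this assay, > 50000 nM; this is the limit of > 50000 nM in this assay, at which 1 of the 3 values shown sits.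

Compound 4 `Clc1ccc2[nH]c(-c3nc(-c4ccccc4)no3)cc2c1` differs from compound 3 by chloro in place of hydroxy on an aromatic carbon. Among the compounds with values here, one measured step bears on this: an at least 1.6-fold higher number from compound 1 to compound 2 (0.21 log units; that floor lies within the scatter), where chloro enters at the same place on the shared core; its size is open-ended because of the limit of > 50000 nM in this assay, at which 1 of the 3 values shown sits. Hydroxy and chloro are not compared directly anywhere in the set, and compound 3 and compound 1 differ in two places, so the two values only show that the hydroxy compound sits lower. Chloro entering at this position so far has not lowered the number, so the number for compound 4 is expected to rise beyond the scatter rather than fall. Compound 4 is estimated at 32000 nM, with a range of 12000 nM to 60000 nM. The expected step is a 2.5-fold higher number from compound 3 to compound 4 (0.39 log units; beyond the scatter), with a real chance that only a limit is reported.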

Compound 4, half-maximal inhibitory concentration: 23100 nM
Compound 4: the middle estimate sits 1.4-fold (0.14 log units) above what was measured, and the stated range covers the measured number.
By their numbers in this assay, from the lowest: compounds 3, 4 and 1 (each within the scatter of the next, the first and the last beyond it). At a limit, above all of these: compound 2.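

In this assay, chloro in place of hydroxy gives a 1.8-fold higher number from compound 3 to compound 4 (0.25 log units; within the scatter), so with phenyl on the shared core this change removes one hydrogen-bond donor and one hydrogen-bond acceptor without a step beyond the scatter. With chloro held at this position, phenyl in place of methyl gives an at least 2.1-fold lower number from compound 2 to compound 4 (0.33 log units; beyond the scatter), and chloro here now has a measured number with phenyl present. Compound 2 remains a limit, so that step gives only a floor: the limit of > 50000 nM in this assay, at which 1 of the 4 values shown sits.

The compounds shown leave open how an amine or a carboxylic acid at this position would compare with hydroxy and chloro. They also leave open whether hydrogen at this position, with phenyl on the shared core, would fall within the scatter of compound 3 and compound 4.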